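Z to E change on the stilbene double bond of compound 1

The source may report more compounds than this note shows. Statements on the series, on what has been measured and on what is new or still open speak of the compounds shown alone.

Compound 1 `CCNC(=O)Nc1ccc(/C=C\c2cc(OC)c(OC)c(OC)c2)cc1` carries a (ethylcarbamoyl)amino group on the aromatic carbon and gives the highest number of the three measured compounds in a functional assay on HT-29 cells (Homo sapiens) for inhibition, read by sulforhodamine B assay, with a stated time of 48 h; a lower number here means a stronger inhibitor, a higher number a weaker inhibitor: compound 1 gives 21000 nM. Compound 2 `Cc1cc(C)cc(/C=C\c2ccc(N3CCNC3=O)cc2)c1` gives 8.4 nM. Compound 3 `COc1cc(/C=C\c2ccc(N3CCNC3=O)cc2)cc(OC)c1OC` keeps the trimethoxy-bearing ring of compound 1; in this assay compound 3 gives 1.7 nM. Among the compounds with values here, the only single-point step measured is a 12000-fold lower number from compound 1 to compound 3 (4.09 log units; beyond the scatter), a change of the group on the aromatic carbon rather than of the double bond.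

Compound 4 `CCNC(=O)Nc1ccc(/C=C/c2cc(OC)c(OC)c(OC)c2)cc1` is the next compound for this assay. Its relation to compound 1 is the two compounds have the same atoms and bonds and differ only in configuration as drawn: 1 of 1 stereo elements differ; a double bond is drawn Z in compound 1 and E in compound 4. Within the data shown here, none of the measured steps touches the configuration of the double bond, so no measured step bears directly on this change, and the expectation rests on compound 1 alone as the anchor. The step is expected to go toward a higher number or to stay within the scatter; a lower number is not expected, so the expected step is a 2.4-fold higher number from compound 1 to compound 4 (0.38 log units; beyond the scatter). Compound 4 is therefore estimated at 50000 nM, with a range from 15000 nM to 200000 nM, and a real chance that only a limit is returned.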

Compound 4, half-maximal inhibitory concentration: 12000 nM
The estimate for compound 4 lay 4.2-fold (0.62 log units) above the measured number; the whole stated range lies above it.
By their numbers in this assay, from the lowest: compound 3; then compound 2; then compounds 4 and 1 (each within the scatter of the next).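

In this assay, the configuration of the stilbene double bond is now read directly, and the step is a 1.8-fold lower number from compound 1 to compound 4 (0.24 log units; within the scatter), so with the (ethylcarbamoyl)amino group on the aromatic carbon the Z and E forms are not separated. Set against a 12000-fold lower number from compound 1 to compound 3 (4.09 log units; beyond the scatter), which changes that group and leaves the double bond as drawn, the configuration change is a small step in this pair. The reading concerns the double bond alone: the fact that compounds 1 and 4 differ only in the configuration as drawn.

Whether configuration matters once the 2-oxoimidazolidin-1-yl group is present stays open, as compound 2 and compound 3 are shown only with the Z double bond. Also open, on these data alone, is how a simple amine or a carboxylic acid would read on that aromatic carbon in place of the (ethylcarbamoyl)amino group.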